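Methoxypyridinyl for methoxyphenyl on the shared amine

The source may hold more compounds than are shown below. What is called first, only, known or untested is meant among the compounds shown, and "the series" means these compounds.

Working notes on a short series sharing one core, read in an ADME assay on L02 cells (Homo sapiens) for cytotoxicity, read by MTT assay, with a stated time of 72 h; on this read-out lower numbers stand for stronger inhibition and higher numbers for weaker inhibition. Among the measured compounds shown here, compound 1 `C=CC(=O)Nc1cccc(Oc2nc(Nc3cccc(OC)c3)nc3c2CSCC3)c1` is the only member with a number: compound 1 gives 48900 nM in this assay. Compound 2 `CC/C=C/C(=O)Nc1cccc(Oc2nc(Nc3cccc(OC)c3)nc3c2CSCC3)c1` reaches only a limit of this assay, reported as > 50000 nM. Compound 3 `COc1cccc(Nc2nc3c(c(Oc4cccc(NC(=O)C=C(C)C)c4)n2)CSCC3)c1` likewise stops at a limit, reported as > 50000 nM. The measured steps all alter the group on the carbonyl carbon: an at least 1.0-fold higher number from compound 1 to compound 2 (0.00 log units; that floor lies within the scatter), and an at least 1.0-fold higher number from compound 1 to compound 3 (0.00 log units; that floor lies within the scatter), while a step that the two limits leave unreadable from compound 2 to compound 3. Two of the three values sit at the limit of > 50000 nM in this assay, at which 2 of the 3 values shown sit, so no step beyond the scatter can be read anywhere in the measured set.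

Compound 4 `C=CC(=O)Nc1cccc(Oc2nc(Nc3ccc(OC)nc3)nc3c2CSCC3)c1` moves the variation elsewhere: 6-methoxypyridin-3-yl in place of 3-methoxyphenyl on a nitrogen on an aromatic ring. For the measured compounds named here, none of the measured steps touches this nitrogen, so there is no direct precedent; the series only shows that all three measured members lie at or near the limit of this assay. Compound 4 is therefore expected to sit in the same region, with the step of a 1.0-fold higher number from compound 1 to compound 4 (0.01 log units; within the scatter) estimated as nothing beyond the scatter. The estimate for compound 4 in this assay is 50000 nM, with a range of 24000 nM to 100000 nM, and a fair chance that only a limit is reported.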

Compound 4, half-maximal inhibitory concentration: > 50000 nM
Compound 4: only a limit was reported; the forecaster's own chance of this, stated with the estimate: 55%; the middle value lies on the limit itself.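

Among the compounds shown here, this is the first reading of a change on the nitrogen on an aromatic ring, as all earlier steps altered the group on the carbonyl carbon. In this assay, for the compounds shown here, 6-methoxypyridin-3-yl in place of 3-methoxyphenyl gives an at least 1.0-fold higher number from compound 1 to compound 4 (0.00 log units; that floor lies within the scatter), so placing a hetero atom in this aromatic ring, with the hydrogen-bond acceptor count going from 1 to 2, produces no step that can be read beyond the scatter. This position therefore behaves like the carbonyl substituent so far, although the floor says only that no drop in the number is visible, and the series now gathers even more tightly at one end of the range: the limit of > 50000 nM in this assay, at which 3 of the 4 values shown sit.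

How far compound 4 lies past its limit cannot be told, so any real gap from the other limit compounds stays hidden. Going by these compounds, it also remains open whether a group such as a primary amine, a carboxylic acid or a longer alkoxy chain, in place of 6-methoxypyridin-3-yl on this nitrogen, would bring the read-out into a range where a step could be sized.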